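The source may report more compounds than this note shows. Statements on the series, on what has been measured and on what is new or still open speak of the compounds shown alone.

Working notes on the series. Compound 1 `CC(C)(C)OC(=O)N1CCC(O[C@H]2CC[C@H](Oc3ccc(S(C)(=O)=O)cc3F)CC2)CC1` gives 113% in a functional assay on isolated protein for agonist activity at Glucose-dependent insulinotropic receptor (Homo sapiens), read by HTRF and cAMP accumulation; on this read-out lower numbers stand for smaller maximal responses and higher numbers for larger maximal responses. Compound 2 `CC(C)(C)OC(=O)N1CCC(O[C@H]2CC[C@H](Oc3ccc(S(C)(=O)=O)nn3)CC2)CC1` gives 97% in this assay. Compound 3 `C[C@H](CF)OC(=O)N1CCC(O[C@H]2CC[C@H](Oc3cnc(S(C)(=O)=O)cn3)CC2)CC1` gives 108% in this assay, the second highest of the three numbers: its gap to compound 1 lies within the scatter, while its gap to compound 2, which lies lower, is beyond the scatter. Compound 4 `CS(=O)(=O)c1cnc(O[C@H]2CC[C@H](OC3CCN(CC4(C(F)(F)F)CC4)CC3)CC2)cn1` differs from compound 3 by a group of 8 heavy atoms (5 carbon, 3 fluorine; one three-membered non-aromatic ring of carbon only) in place of a group of 7 heavy atoms (4 carbon, 2 oxygen, 1 fluorine; no ring), on an amine nitrogen in a ring. Going by the values given here, no step between measured compounds isolates this change, so there is no direct precedent for it. All three measured compounds sit in a narrow band, so the step of a number 4 percentage points lower from compound 3 to compound 4 (within the scatter) is expected to be none beyond the scatter. Compound 4 is therefore expected at 104%, between 88% and 120%.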

Compound 4, largest response reached (Emax), in percent of the reference or control that the assay uses: 116%
Beside the measured number, compound 4's estimate is 12 percentage points below it; the measured number falls inside the stated range.
By their numbers in this assay, from the lowest: compound 2; then compounds 3, 1 and 4 (each within the scatter of the next).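

In this assay the change at the amine nitrogen in a ring gives a number 8 percentage points higher from compound 3 to compound 4 (within the scatter), so the maximal response holds with (1-(trifluoromethyl)cyclopropyl)methyl, which has 0 hydrogen-bond acceptors, in place of a group with 2. Compound 4 is the first shown without oxygen or a double bond in the group on this nitrogen, so neither is required for a full response here. Nothing measured explains this result. On these data alone, a benzyl group or a longer chain on this nitrogen remains open. So does whether compound 4's group holds the response with the other aromatic rings of compound 1 and compound 2.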